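Urea series: fluoro for dimethylamino on the central ring

The source may hold more compounds than are shown below. What is called first, only, known or untested is meant among the compounds shown, and "the series" means these compounds.

compound 1 `COc1cccc(CNC(=O)Nc2ccc(C3=NC=NC4NC=CC34)cc2)c1`: 188 nM; 188 nM (2 entries)
compound 2 `COc1cccc(CNC(=O)Nc2ccc(-c3cn[nH]c3)cc2N(C)C)c1`: < 1 nM

In an assay on isolated protein for inhibition of Rho-associated protein kinase 2 (Homo sapiens), read by HTRF, with a stated time of 4 h (a lower number here means a stronger inhibitor, a higher number a weaker inhibitor), compound 1 gives 188 nM; 188 nM (2 entries). Compound 2 reaches a limit of the assay rather than a number, < 1 nM. Compound 2 therefore stands at the lower edge of what this assay reports, as the entry the limit of < 1 nM in this assay, at which 1 of the 2 values shown sits, shows, and a second entry for it also carries no single number.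

Compound 3 `COc1cccc(CNC(=O)Nc2ccc(-c3cn[nH]c3)cc2F)c1` differs from compound 2 in one place: fluoro in place of dimethylamino on an aromatic carbon. Among the measured compounds shown here, no pair of measured compounds differing in one place is available, so no measured step guides this change. Because compound 2 sits at the limit (the limit of < 1 nM in this assay, at which 1 of the 2 values shown sits), any movement this assay can resolve would be toward a weaker number. A modest step toward weaker inhibition is expected, roughly at the edge of the scatter, with a fair chance that the limit is reported again. Compound 3 is expected at 3 nM, range 0.7 nM to 15 nM, meaning an expected step of an at least 3.0-fold higher number from compound 2 to compound 3 (0.47 log units; beyond the scatter).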

Compound 3, half-maximal inhibitory concentration: < 1 nM
Compound 3 ended at the assay's limit; the forecaster's own chance of this, stated with the estimate: 25%; middle value at least 3.0-fold (0.47 log units) from the limit.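

The step from compound 2 to compound 3 cannot be read, since both compounds stand at a limit of this assay and not at a number: the limit of < 1 nM in this assay, at which 2 of the 3 values shown sit.

The compounds shown leave open how far fluoro and dimethylamino on this aromatic carbon differ in inhibition, and in which direction.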